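Swapping One Triazole Isomer for Another on the Shared Core

This account rests on a few compounds, and the source may have more. Where it says the series, first, only, none or still open, it means among the compounds named here.

Of the compounds shown here, three have been measured in an ADME assay on microsomes from liver (Rattus norvegicus) for metabolic stability, read by LC-MS; on this read-out lower numbers stand for slow clearance and higher numbers for fast clearance. Compound 1 `COc1cc(N2CCN(C(=O)Cn3cnc4cccc(C(F)(F)F)c43)CC2)ccc1-c1cnc(C)o1` gives 7 mL.min-1.g-1 in this assay. Compound 3 `COc1cc(N2CCN(C(=O)Cn3cnc4ccc(C(F)(F)F)cc43)CC2)ccc1-c1cnc(C)o1` gives 23 mL.min-1.g-1. Compound 2 `COc1cc(N2CCN(C(=O)N[C@@H](C)c3cccc4ccccc34)CC2)ccc1-n1cc(C)nn1` gives 230 mL.min-1.g-1, the highest number of the three, and its distance to each of compound 3 and compound 1 lies beyond the usual scatter. Compound 4 `COc1cc(N2CCN(C(=O)N[C@@H](C)c3cccc4ccccc34)CC2)ccc1-n1cnc(C)n1` keeps all of compound 2 except one five-membered ring: 3-methyl-1H-1,2,4-triazol-1-yl in place of 4-methyl-1H-1,2,3-triazol-1-yl on an aromatic carbon. Among the measured compounds shown here, no measured pair shows what this swap does. The two rings carry the same counted atoms and acceptors, so the step expected from compound 2 to compound 4, a 1.2-fold lower number from compound 2 to compound 4 (0.06 log units; within the scatter), is no larger than the scatter, in no definite direction. Compound 4 is therefore estimated at 200 mL.min-1.g-1, within a range from 70 mL.min-1.g-1 to 500 mL.min-1.g-1.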

Compound 4, intrinsic clearance in microsomes: 110 mL.min-1.g-1
Beside the measured number, compound 4's estimate is 1.8-fold (0.26 log units) above it; measured number inside the range.
By their numbers in this assay, from the lowest: compound 1; then compound 3; then compound 4; then compound 2.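

Even with the same counted atoms and acceptors, rearranging this one five-membered ring, ortho to a methoxy group, changes the number in this assay with a 2.1-fold lower number from compound 2 to compound 4 (0.32 log units; beyond the scatter) as a modest but readable step. So this position responds to how the triazole is arranged, not only to what it contains. Nothing available explains why the swap has this effect. Still open, from the compounds shown here alone, is whether a tetrazole or an aminomethyl group here would lower the number further, and whether the same swap behaves alike with other groups on the shared core.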